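Changing the aryl group on the amine nitrogen: compound 4

A few compounds are considered here, and "the series" means these few. Any claim that something is new, unique, unknown or untested is made for them only; others in the source may bear on it.

Compound 1 `O=C1C=C(Nc2ccc(I)cc2)C(=O)c2c1nc1n2[C@H]2OC[C@@H](O)[C@H]2OC1`: 2230 nM
Compound 2 `Cc1ccc(NC2=CC(=O)c3nc4n(c3C2=O)[C@H]2OC[C@@H](O)[C@H]2OC4)cc1C`: 2080 nM
Compound 3 `O=C1C=C(Nc2cccc(Cl)c2)C(=O)c2c1nc1n2[C@H]2OC[C@@H](O)[C@H]2OC1`: 4720 nM

In a functional assay on MCF7 cells (Homo sapiens) for inhibition, read by sulforhodamine B assay (on this read-out higher numbers stand for weaker inhibition and lower numbers for stronger inhibition), compound 3 gives the highest of the three numbers. The steps leading to it were a 2.1-fold higher number from compound 1 to compound 3 (0.33 log units; beyond the scatter) and a 2.3-fold higher number from compound 2 to compound 3 (0.36 log units; beyond the scatter), so the 3-chlorophenyl compound gives modestly higher numbers than either of the other two. Compound 4 `O=C1C=C(Nc2ccccc2F)C(=O)c2c1nc1n2[C@H]2OC[C@@H](O)[C@H]2OC1` differs from compound 3 by 2-fluorophenyl in place of 3-chlorophenyl on an amine nitrogen. Among the compounds with values here, no measured step involves a 2-fluorophenyl group, so only the narrow spread among the three aryl groups bears on it. Compound 4 is expected to stay close to compound 3, with a possible small return toward the others, a 1.3-fold lower number from compound 3 to compound 4 (0.13 log units; within the scatter), giving an estimate of 3500 nM in this assay, with a range of 1300 nM to 9500 nM.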

Compound 4, half-maximal inhibitory concentration: 3640 nM
The estimate for compound 4 lay 1.0-fold (0.02 log units) below the measured number; measured number inside the range.
By their numbers in this assay, from the lowest: compounds 2, 1, 4 and 3 (each within the scatter of the next, the first and the last beyond it).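

In this assay the 2-fluorophenyl group lies within the scatter of all three earlier aryl groups, with a 1.3-fold lower number from compound 3 to compound 4 (0.11 log units; within the scatter) and a 1.8-fold higher number from compound 2 to compound 4 (0.24 log units; within the scatter) and a 1.6-fold higher number from compound 1 to compound 4 (0.21 log units; within the scatter) as its steps. Compound 4 therefore bridges the modest gaps that set compound 3 apart from compound 1 and compound 2, so on this amine nitrogen the four aryl groups form one continuous narrow spread, although compound 3 remains beyond the scatter of those two. Nothing available accounts for these small differences. From the compounds shown here alone, whether an unsubstituted phenyl, a cyclohexyl or a phenyl carrying a carboxylic acid would stay within this spread remains open.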